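Loss of a ring hydroxy in a macrocyclic lactone series

The compounds below may be only part of what the source reports. "The series", "measured", "known", "first", "only" and "open" are said of these compounds alone.

Of the compounds shown here, three of a shared core have been tested in a functional assay on HL-60 cells (Homo sapiens) for cytotoxicity, read by MTT assay; on this read-out lower numbers stand for stronger inhibition and higher numbers for weaker inhibition. Compound 1 `C=C1C(=O)O[C@@H]2[C@@H]1C[C@H](O)[C@@](O)(CO)CC/C=C(\C)CC/C=C(\C)[C@@H]2O` in this assay gives only a limit, > 10 ug/mL. Compound 2 `C=C1C(=O)O[C@@H]2[C@@H]1C[C@H]1O[C@]1(CO)CC/C=C(\C)CC/C=C(\C)[C@H]2O` in this assay gives 5.2 ug/mL, and compound 3 `C=C1C(=O)O[C@@H]2[C@@H]1C[C@H]1O[C@]1(CO)CC/C=C(\C)CC/C=C(\C)[C@@H]2O` gives 5.1 ug/mL. Compound 3 stands at the lowest of the two numbers, with compound 2 within the scatter of it; the step of a 1.0-fold lower number from compound 2 to compound 3 (0.01 log units; within the scatter) rests on the fact that compounds 2 and 3 differ only in the configuration as drawn and shows no change beyond the scatter.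

Compound 4 `C=C1C(=O)O[C@H]2C/C(C)=C/CC/C(C)=C/CC[C@@]3(CO)O[C@@H]3C[C@H]12` differs from compound 3 by hydrogen in place of hydroxy on a saturated ring carbon. Among the measured compounds shown here, no measured step concerns the removal of this hydroxy; the only measured step, from compound 2 to compound 3, alters configuration alone and was within the scatter. The data therefore give no direction for this change, and compound 4 is expected to stay near compound 3, with the expected step of a 1.1-fold higher number from compound 3 to compound 4 (0.03 log units; within the scatter) not beyond the scatter. In this assay compound 4 is estimated to give 5.5 ug/mL, within a range of 2.2 ug/mL to 14 ug/mL.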

Compound 4, half-maximal inhibitory concentration: 2.3 ug/mL
Compound 4: middle estimate off by 2.4-fold (0.38 log units), on the high side, and the stated range covers the measured number.
By their numbers in this assay, from the lowest: compound 4; then compounds 3 and 2 (each within the scatter of the next). At a limit, above all of these: compound 1.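

In this assay, hydrogen in place of hydroxy on this saturated ring carbon gives a 2.2-fold lower number from compound 3 to compound 4 (0.35 log units; beyond the scatter), and likewise a 2.3-fold lower number from compound 2 to compound 4 (0.35 log units; beyond the scatter). A modest change beyond the scatter therefore appears from either drawn configuration of the hydroxy-bearing carbon, whereas the earlier pair had shown no change beyond the scatter at this position, a reading that rests on one fact: the fact that compounds 2 and 3 differ only in the configuration as drawn. This position is thus one where the read-out can move, and the move seen here is toward a lower number on loss of the hydroxy.

Whether hydroxy removal alone sets this number stays open, since the compounds shown carry nothing else at this carbon, such as a methoxy group, an amine or a fluorine atom. Compound 1 gives only a limit, > 10 ug/mL, and so offers no number to set beside the others.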